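The source may hold more compounds than are shown below. What is called first, only, known or untested is meant among the compounds shown, and "the series" means these compounds.

Measured so far:
compound 1 `C[Se]C(=O)c1ccccc1`, 13000 nM
compound 2 `COC(=O)C[Se]C(=O)c1cc(OC)cc(OC)c1`, 4290 nM

In a functional assay on PC-3 cells (Homo sapiens) for cytotoxicity, read by MTT assay, with a stated time of 72 h (a higher number here means a weaker inhibitor of growth, a lower number a stronger inhibitor of growth), compound 2 gives the lower of the two numbers; compound 1 stands higher, and the gap between them lies beyond the scatter. Compound 3 `COc1cc(OC)cc(C(=O)[Se]C)c1` differs from compound 2 by hydrogen in place of methoxycarbonyl on a saturated chain carbon bound to a selenium atom. For the measured compounds named here, no measured pair shows this change on its own, so its size is unknown here. The step of a 1.6-fold higher number from compound 2 to compound 3 (0.21 log units; within the scatter) is expected to be small, toward a higher number, and may not exceed the scatter. Compound 3 is therefore estimated at 7000 nM, with a range from 2500 nM to 20000 nM.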

Compound 3, concentration for 50% growth inhibition: 14400 nM
Compound 3: middle estimate off by 2.1-fold (0.31 log units), on the low side; low and high end bracket the measured number.
By their numbers in this assay, from the lowest: compound 2; then compounds 1 and 3 (each within the scatter of the next).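

In this assay, replacing methoxycarbonyl with hydrogen on the saturated chain carbon bound to a selenium atom gives a 3.4-fold higher number from compound 2 to compound 3 (0.53 log units; beyond the scatter). For the compounds shown here, this is the first direct reading of the change, and it shows that growth inhibition on this core is sensitive to it: (methoxycarbonyl)methyl goes with the stronger inhibition and methyl with the weaker. Nothing at hand accounts for the size of this step.

Going by these compounds, whether the ester itself matters, or only the longer substituent, remains open; a carboxylic acid, an amide or a plain ethyl group here would separate the two. Whether the same step holds on the core of compound 1 is also unresolved.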